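This account rests on a few compounds, and the source may have more. Where it says the series, first, only, none or still open, it means among the compounds named here.

Measured in a functional assay on MCF7 cells (Homo sapiens) for antiproliferative activity, with a stated time of 48 h; a higher number here means a weaker inhibitor of growth, a lower number a stronger inhibitor of growth:

compound 1 `Cc1cc(O)c(C2=NN(c3ccc(S(N)(=O)=O)cc3)C(c3ccccc3Cl)C2)cc1Cl`: 3330 nM
compound 2 `Cc1cc(O)c(C2=NN(c3ccc(S(N)(=O)=O)cc3)C(/C=C/c3ccccc3)C2)cc1Cl`: 16100 nM
compound 3 `COc1ccc(C2CC(c3cc(Cl)c(C)cc3O)=NN2c2ccc(S(N)(=O)=O)cc2)cc1OC`: 13600 nM

Compound 3 stands second highest of the three numbers. Its nearest neighbour is compound 2, with a 1.2-fold lower number from compound 2 to compound 3 (0.07 log units; within the scatter); the two are not separable. Its furthest is compound 1, with a 4.1-fold higher number from compound 1 to compound 3 (0.61 log units; beyond the scatter). The related step of a 4.8-fold higher number from compound 1 to compound 2 (0.68 log units; beyond the scatter) is of similar size, so the two exchanges of the whole aryl group on the saturated ring carbon both weakened growth inhibition to about the same extent.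

Compound 4 `COc1ccc(C2CC(c3cc(Cl)c(C)cc3O)=NN2c2ccc(S(N)(=O)=O)cc2)c(OC)c1OC` differs from compound 3 by methoxy in place of hydrogen on an aromatic carbon. Within the data shown here, none of the measured steps adds a substituent to that aryl group; each of them replaces the group as a whole, so no step bears directly on this change. Nothing in the data supports a shift beyond the scatter in this assay in either direction. The expected step is a 1.0-fold higher number from compound 3 to compound 4 (0.01 log units; within the scatter). Compound 4 is therefore estimated at 14000 nM, with a range from 5000 nM to 40000 nM.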

Compound 4, concentration for total growth inhibition: 10300 nM
Compound 4: middle estimate off by 1.4-fold (0.13 log units), on the high side; low and high end bracket the measured number.
By their numbers in this assay, from the lowest: compound 1; then compounds 4, 3 and 2 (each within the scatter of the next).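

In this assay, among these compounds, methoxy in place of hydrogen on an aromatic carbon, ortho to a large group and to a methoxy group, gives the first step that adds a substituent to the aryl group rather than replacing it: a 1.3-fold lower number from compound 3 to compound 4 (0.12 log units; within the scatter). The position therefore takes the extra methoxy with no separable shift, and the 2,3,4-trimethoxyphenyl group also cannot be separated from 2-phenylethenyl, at a 1.6-fold lower number from compound 2 to compound 4 (0.19 log units; within the scatter). Against 2-chlorophenyl, the gap stays beyond the scatter, at a 3.1-fold higher number from compound 1 to compound 4 (0.49 log units; beyond the scatter), so the added methoxy does not bring this series within reach of compound 1.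

No measurement at hand explains these steps.

As far as these compounds go, whether an amine, a carboxylic acid or a longer chain such as butoxy at this aromatic carbon would read like methoxy remains open.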